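Swapping chlorine for fluorine on a chalcone-like pyrazole

The source may report more compounds than this note shows. Statements on the series, on what has been measured and on what is new or still open speak of the compounds shown alone.

Compound 1, `COc1cc(-c2cc(/C=C/C(=O)c3ccc(Cl)c(Cl)c3)[nH]n2)cc(OC)c1OC`: 89%
Compound 2, `COc1ccc(-c2cc(/C=C/C(=O)c3ccc(N)cc3)[nH]n2)cc1OC`: 80%

Both compounds were tested in a functional assay on A498 cells (Homo sapiens) for cytotoxicity, read by sulforhodamine B assay, with a stated time of 48 h, tested at 0.1 uM; on this read-out higher numbers stand for a weaker effect at the one concentration tested and lower numbers for a stronger effect. Compound 1 gives 89%, and compound 2 gives 80%. The gap between these two numbers falls within the usual scatter of repeated measurements, so on the data at hand compound 1 and compound 2 cannot be told apart; both leave most of the cells growing at the single concentration tested.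

Compound 3, `COc1cc(-c2cc(/C=C/C(=O)c3ccc(F)c(F)c3)[nH]n2)cc(OC)c1OC`, has not yet been measured in this assay. It is related to compound 1 by one change: 3,4-difluorophenyl in place of 3,4-dichlorophenyl on a carbonyl carbon. Among the compounds with values here, no measured pair in this set shows what such a swap of one halogen for another does in this assay, so there is no directly comparable step to lean on.

Given that compound 1 already sits near the weak end of the scale, the expected step is small, within the scatter, in no particular direction, no change at the digits printed from compound 1 to compound 3 (within the scatter). The estimate for compound 3 is therefore 89%, with a plausible range from 74% to 102%.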

Compound 3, a percentage reported as activity, at one concentration (the size of the read-out at that concentration, not a potency): 96%
Compound 3: the middle estimate sits 7 percentage points below what was measured; the range from low to high includes it.
By their numbers in this assay, from the lowest: compounds 2, 1 and 3 (each within the scatter of the next, the first and the last beyond it).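

In this assay, within the data shown here, putting 3,4-difluorophenyl in place of 3,4-dichlorophenyl on a carbonyl carbon gives a number 7 percentage points higher from compound 1 to compound 3 (within the scatter); this is the first direct one-place comparison in the set, and it shows that the two halogen pairs cannot be told apart at this position in this test. Both compounds sit at the weak end of the scale at the single concentration used, so this one reading can hide any difference in effect that would appear only at other concentrations. Nothing at hand links the result to a measured property of either group, so the comparison describes what was seen but does not explain it.

The compounds shown leave open whether any group at this position can give a clearly stronger effect, for example a plain phenyl or a phenyl carrying a carboxylic acid in place of the two halogens. They also leave open how compound 1 and compound 3 would compare at other concentrations, where the effect of each could be stronger or weaker than at the single concentration used.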